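Paring the Amide Nitrogen of Compound 3

The source may report more compounds than this note shows. Statements on the series, on what has been measured and on what is new or still open speak of the compounds shown alone.

Of the compounds shown here, three sharing one core have been tested in a functional assay for inhibition of nuclear factor NF-kappa-B complex (Homo sapiens); a lower number here means a stronger inhibitor, a higher number a weaker inhibitor. Compound 1 `COc1ccc2c(c1)OC(c1cc(OC)c(OC)c(OC)c1)C(C=O)=C2` gives 13500 nM. Compound 2 `COc1ccc2c(c1)OC(c1cc(OC)c(OC)c(OC)c1)C(C(N)=O)=C2` reaches only the limit of the assay, > 50000 nM. Compound 3 `COc1ccc2c(c1)OC(c1cc(OC)c(OC)c(OC)c1)C(C(=O)N(C)OC)=C2` gives 11700 nM, standing with compound 1 within the scatter. Compound 4 `CNC(=O)C1=Cc2ccc(OC)cc2OC1c1cc(OC)c(OC)c(OC)c1` differs from compound 3 by hydrogen in place of methoxy on an amide-type nitrogen. Within the data shown here, two steps bear on this change: an at least 4.2-fold lower number from compound 2 to compound 3 (0.63 log units; beyond the scatter), while a 1.2-fold lower number from compound 1 to compound 3 (0.06 log units; within the scatter). In its substitution on the amide-type nitrogen compound 4 lies between compound 2 and compound 3, so a modest rise in the number is expected. The step is estimated as a 2.1-fold higher number from compound 3 to compound 4 (0.33 log units; beyond the scatter). Compound 4 is therefore expected to give 25000 nM, within 10000 nM to 60000 nM.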

Compound 4, half-maximal inhibitory concentration: > 50000 nM
Compound 4: no number, only a limit; the forecaster's own chance of this, stated with the estimate: 25%; at least 2.0-fold (0.30 log units) between middle value and limit.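

In this assay the methoxy on the amide-type nitrogen proves to matter, with an at least 4.2-fold higher number from compound 3 to compound 4 (0.63 log units; beyond the scatter), and the distance from the aldehyde compound is similar, with an at least 3.7-fold higher number from compound 1 to compound 4 (0.56 log units; beyond the scatter). Compound 4 gives only a limit, > 50000 nM. A methyl alone on that nitrogen therefore does not keep the level of compound 3.

What methyl in place of hydrogen does on that nitrogen cannot be read, since compound 2 and compound 4 both rest at one limit: the limit of > 50000 nM in this assay, at which 2 of the 4 values shown sit. On these data alone, whether a dimethylamino or a methoxyamino group on the carbonyl carbon would hold the level of compound 3 remains open.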